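Tolerability notes on the shared core, compound 3 to compound 4

The source may hold more compounds than are shown below. What is called first, only, known or untested is meant among the compounds shown, and "the series" means these compounds.

The set shares one core. Compound 1 is `COc1ccc([C@H]2CC(=O)N(Cc3cccc(N)c3)C2)cc1OC1CCCC1`, compound 2 is `COc1ccc([C@H]2CC(=O)N(Cc3cccc([N+](=O)[O-])c3)C2)cc1OC1CCCC1`, compound 3 is `COc1ccc([C@H]2CC(=O)N(c3cccc(NCC4CCOC4)c3)C2)cc1OC1CCCC1`, and compound 4, not yet measured, is `COc1ccc([C@H]2CC(=O)N(c3cccc(NS(=O)(=O)c4ccccc4Br)c3)C2)cc1OC1CCCC1`. In a functional assay on HEK293 cells (Homo sapiens) for cytotoxicity (a higher number here means that more compound is tolerated, a lower number that less compound is tolerated), compound 1 reports a limit of > 10000 nM. Compound 2 also reports a limit, > 10000 nM. Compound 3 likewise stands at a limit of > 10000 nM. Going by the values given here, the one step that differs in a single place, a step that the two limits leave unreadable from compound 1 to compound 2, cannot be read, since both of its ends rest at the limit. The whole set sits the same way: the limit of > 10000 nM in this assay, at which 3 of the 3 values shown sit. Compound 3 therefore stands exactly where the other two stand, with no number beneath the limit to set it apart.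

The change from compound 3 to compound 4 is (2-bromophenyl)sulfonyl in place of (oxolan-3-yl)methyl on a nitrogen on an aromatic ring. Among the compounds with values here, no measured step covers a change of that kind, and the single measured step gives no size or direction to lean on. Compound 4 is expected to reach the limit as well, the estimated step being a step that the limit leaves unreadable from compound 3 to compound 4. The estimate for compound 4 in this assay is 12000 nM, with an expected range of 4000 nM to 40000 nM.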

Compound 4, half-maximal cytotoxic concentration: > 10000 nM
Compound 4 was reported as a limit; the forecaster's own chance of this, stated with the estimate: 80%; the middle value is on the limit's open side.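

No step can be read from compound 3 to compound 4, since both rest at a limit: the limit of > 10000 nM in this assay, at which 4 of the 4 values shown sit.

The compounds shown leave open where their actual values lie beyond that limit, and whether any change on the shared core alters tolerance in this assay.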